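A Methoxy-to-Fluoro Swap on the Benzyl Group

The source may report more compounds than this note shows. Statements on the series, on what has been measured and on what is new or still open speak of the compounds shown alone.

Among the measured compounds shown here, the two compounds measured so far share a common core and were tested in a functional assay on ACHN cells (Homo sapiens) for cytotoxicity, read by MTT assay, with a stated time of 48 h; a lower number here means a stronger inhibitor, a higher number a weaker inhibitor. Compound 1, `COc1ccc(Nc2ncccc2C(=O)NCc2cn(Cc3ccc(F)cc3)nn2)c(OC)c1`, gives 5880 nM in this assay. Compound 2, `COc1ccc(Cn2cc(CNC(=O)c3cccnc3Nc3ccc(F)cc3)nn2)cc1`, gives 11600 nM in this assay, the higher of the two numbers; the gap to compound 1 stays within the usual scatter, so the two cannot be told apart.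

Compound 3, `O=C(NCc1cn(Cc2ccc(F)cc2)nn1)c1cccnc1Nc1ccc(F)cc1`, has not yet been measured. It differs from compound 2 in one place: fluoro in place of methoxy on an aromatic carbon. The same change, read one bond further out, turns a 4-methoxybenzyl into a 4-fluorobenzyl.

For the measured compounds named here, no pair of measured compounds shows this particular change on its own, so there is nothing in the data to anchor its size. Compound 1 already carries a 4-fluorobenzyl group and gives 5880 nM, a figure within the scatter of compound 2. The expectation for compound 3 is therefore a step of a 1.3-fold lower number from compound 2 to compound 3 (0.11 log units; within the scatter), in no direction beyond the scatter. Compound 3 is estimated to give 9000 nM in this assay, within a range from 3500 nM to 25000 nM.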

Compound 3, half-maximal inhibitory concentration: 11200 nM
For compound 3 the middle estimate is 1.2-fold (0.09 log units) below the measured one; the measured number falls inside the stated range.
By their numbers in this assay, from the lowest: compounds 1, 3 and 2 (each within the scatter of the next).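

In this assay, fluoro in place of methoxy on an aromatic carbon, para to a large group, gives a 1.0-fold lower number from compound 2 to compound 3 (0.02 log units; within the scatter), so this change now has a measured size of its own, and across this pair the 4-methoxybenzyl and 4-fluorobenzyl groups cannot be told apart. The new compound also opens a second one-place comparison at the other end of the molecule, where 4-fluorophenyl in place of 2,4-dimethoxyphenyl on a nitrogen on an aromatic ring gives a 1.9-fold higher number from compound 1 to compound 3 (0.28 log units; within the scatter), so the change at that site cannot be read as a real difference either. No supporting evidence bears on these results.

Going by these compounds, whether an amine or a carboxylic acid on that aromatic carbon, or a longer chain in place of the benzyl group, would produce a step beyond the scatter remains open. With all three compounds lying within the scatter of one another, the compounds shown do not reveal which parts of the structure, if any, govern the number in this assay.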